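A few compounds are considered here, and "the series" means these few. Any claim that something is new, unique, unknown or untested is made for them only; others in the source may bear on it.

Compound 1 `Nc1nc(N)c2c(-c3cc4ccccc4o3)cn([C@@H]3O[C@H](CO)[C@@H](O)[C@H]3O)c2n1` — in a functional assay on HeLa S3 cells (Homo sapiens) for antiproliferative activity, read by XTT assay, with a stated time of 72 h (on this read-out lower numbers stand for stronger inhibition and higher numbers for weaker inhibition), compound 1 gives > 20000 nM, which is a limit of the assay and not a number.
Compound 2 `Cc1nc(N)c2c(-c3cc4ccccc4o3)cn([C@@H]3O[C@H](CO)[C@@H](O)[C@H]3O)c2n1` — in this assay compound 2 gives > 20000 nM, again a limit rather than a number.
Compound 3 `O=c1[nH]cnc2c1c(-c1ccco1)cn2[C@@H]1O[C@H](CO)[C@@H](O)[C@H]1O` — in this assay compound 3 gives 5780 nM.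

Compound 2 stands at the upper edge of what the assay can report: the limit of > 20000 nM in this assay, at which 2 of the 3 values shown sit. Among the measured compounds shown here, the only measured step between neighbours, a step that the two limits leave unreadable from compound 1 to compound 2, cannot be sized, since both of its ends are limits. Compound 4 `Cc1nc(N)c2c(-c3ccccc3)cn([C@@H]3O[C@H](CO)[C@@H](O)[C@H]3O)c2n1` differs from compound 2 by phenyl in place of 1-benzofuran-2-yl on an aromatic carbon. For the measured compounds named here, no measured step touches this change. Going by the values given here, compound 3 carries a different core and a smaller oxygen-containing ring, and it does give a number, but no single-point step connects it to compound 2 or compound 4, so its value says nothing about this replacement. Among the compounds with values here, with no step to lean on, compound 4 is expected to stay at or near the limit in this assay, the expected step being a step that the limit leaves unreadable from compound 2 to compound 4. The estimate for compound 4 is therefore 30000 nM, within 8000 nM to 100000 nM.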

Compound 4, half-maximal inhibitory concentration: > 20000 nM
Compound 4 ended at the assay's limit; the forecaster's own chance of this, stated with the estimate: 75%; the middle value lies beyond the limit too.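

Compound 4, like compound 2, gives a limit of the assay and not a number, so the change between them cannot be sized: the limit of > 20000 nM in this assay, at which 3 of the 4 values shown sit. The compounds shown leave open whether phenyl and 1-benzofuran-2-yl differ at all in this assay.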